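Methyl in place of cyclopropyl: compound 3 awaits measurement

A few compounds are considered here, and "the series" means these few. Any claim that something is new, unique, unknown or untested is made for them only; others in the source may bear on it.

Measured so far:
compound 1 `CCN1C(=O)CN(Cc2ccc(-c3cccc(CN4CCCCC4)n3)cc2)C1=O`: 2 h
compound 2 `O=C1CN(Cc2ccc(-c3cccc(CN4CCCCC4)n3)cc2)C(=O)N1C1CC1`: 2 h

In an in vitro ADME assay on microsomes from liver (Homo sapiens) for metabolic stability, read by LC-MS, using NADPH, tested at 1 uM (a higher number here means that the compound lasts longer, a lower number that the compound disappears faster), level with compound 1 at the digits available, compound 2 gives 2 h. The two share the same core and differ only in the group on one nitrogen. The unmeasured compound 3 `CN1C(=O)CN(Cc2ccc(-c3cccc(CN4CCCCC4)n3)cc2)C1=O` differs from compound 2 at that same place: methyl in place of cyclopropyl on an amide-type nitrogen in a ring. In words, it has methyl in place of cyclopropyl on an amide-type nitrogen in a ring.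

Among the measured compounds shown here, only one measured step bears on this change: no change at the digits printed from compound 1 to compound 2 (within the scatter). That step put cyclopropyl in place of ethyl on the same nitrogen and stayed within the scatter. For the measured compounds named here, it is a single pair, and no compound with methyl at this place has been measured, so the support is thin. Even so, no step beyond the scatter is expected in this assay, in either direction. The expected step is no change at the digits printed from compound 2 to compound 3 (within the scatter). For compound 3 the estimated half-life is 2 h, with an expected range from 1.1 h to 3.6 h.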

Compound 3, half-life: 1.83 h
For compound 3 the middle estimate is 1.1-fold (0.04 log units) above the measured one, within the range that was stated.
By their numbers in this assay, from the lowest: compounds 3, 1 and 2 (each within the scatter of the next).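

With methyl on the amide-type nitrogen in a ring, this assay now covers three groups at this place, and cyclopropyl to methyl gives a 1.1-fold lower number from compound 2 to compound 3 (0.04 log units; within the scatter) for a change that removes the three-membered ring of carbon only. The earlier pair had compared cyclopropyl only with ethyl, so it could not show whether a group as small as methyl, with its single heavy atom, would stay level with the other two; methyl in place of ethyl gives a 1.1-fold lower number from compound 1 to compound 3 (0.04 log units; within the scatter) and answers that for these compounds. Across methyl, ethyl and cyclopropyl, then, neither the ring nor the number of carbons in the group separates the half-lives in this assay at this place, though that reading reaches no further than compound 1, compound 2 and compound 3.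

The compounds shown leave open whether a group of another kind on this nitrogen, such as an amine, a carboxylic acid or a longer chain, would also stay level in this assay or would step beyond the scatter. They also leave open why these three groups stay level, since no other measurement on these compounds speaks to that question.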